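Swapping the Chlorine Position on a Pyridine-Linked Phenol

A few compounds are considered here, and "the series" means these few. Any claim that something is new, unique, unknown or untested is made for them only; others in the source may bear on it.

Measured compounds:
- Compound 1 `Oc1ccc(-c2cc(-c3cccnc3)nc(-c3ccccc3Cl)c2)cc1`: in an ADME assay on HEK293 cells (Homo sapiens) for cytotoxicity, read by CCK-8 assay and cell counting, with a stated time of 2 days (on this read-out lower numbers stand for stronger inhibition and higher numbers for weaker inhibition), compound 1 stands as "not determined" (no result reported).
- Compound 2 `Oc1ccc(-c2cc(-c3cccs3)nc(-c3ccccc3Cl)c2)cc1`: compound 2 gives 5220 nM in this assay.

Within the data shown here, compound 2 is the only compound here with a number in this assay, so it cannot be ranked against anything else; compound 1 stands beside it without a value. Compound 3 `Oc1ccc(-c2cc(-c3ccc(Cl)cc3)nc(-c3cccs3)c2)cc1` is still unmeasured. It differs from compound 2 in one place: 4-chlorophenyl in place of 2-chlorophenyl on an aromatic carbon. The two compounds are built from the same atoms, only joined differently, so the change is a move of the chlorine around the same ring rather than an addition or removal of anything.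

Among the measured compounds shown here, no step between measured compounds is available to guide the expectation, so the only anchor is compound 2 itself. With that in mind, the step of a 1.0-fold lower number from compound 2 to compound 3 (0.02 log units; within the scatter) is expected to stay within the usual scatter, in neither direction in particular. Compound 3 is therefore estimated at 5000 nM, with a range from 2000 nM to 15000 nM.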

Compound 3, half-maximal inhibitory concentration: 4520 nM
The estimate for compound 3 lay 1.1-fold (0.04 log units) above the measured number; the measured number falls inside the stated range.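

Among these compounds, the first readable step at this position swaps 2-chlorophenyl for 4-chlorophenyl on the aromatic carbon next to the ring nitrogen, and in this assay it comes out as a 1.2-fold lower number from compound 2 to compound 3 (0.06 log units; within the scatter). For these two placements, then, moving the chlorine around its ring leaves the result within the scatter, so this read-out cannot tell the two compounds apart. No supporting measurement is available that would explain this outcome.

On these data alone, it remains open whether the same holds when an amine, a carboxylic acid or a methoxy group takes the place of the chlorine. Compound 1 stands as "not determined" (no result reported), which also leaves open what the thiophen-2-yl group contributes to the result.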